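The source may hold more compounds than are shown below. What is called first, only, known or untested is meant among the compounds shown, and "the series" means these compounds.

Measured so far:
- compound 1, `Cc1ccncc1OC[C@@H]1CCCN1C`: in an assay on K177 cells for activation of Neuronal acetylcholine receptor; alpha4/beta2 (Homo sapiens) (a lower number here means that less compound is needed, a higher number that more compound is needed for the effect), compound 1 gives 2100 nM
- compound 2, `Cc1cncc(OC[C@@H]2CCCN2C)c1`: in this assay compound 2 gives 2300 nM

Compound 2 carries the higher of the two numbers recorded so far, yet its nearest neighbour, compound 1, sits within the scatter of it, so the two readings cannot be told apart. For the measured compounds named here, the pair gives no usable step: both carry a methyl on the shared core, in different places, and both return much the same number.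

The next member is compound 3, `CCCCc1cncc(OC[C@@H]2CCCN2C)c1`. It keeps the core and the methylated pyrrolidine side chain of compound 2 and differs from it in one place: propyl in place of hydrogen on a saturated chain carbon bound to an aromatic carbon, so that the ring substituent of compound 2 grows from methyl to butyl.

Going by the values given here, no measured step of this kind exists, so the expectation rests on the two readings alone. The working assumption is that the longer chain costs activity in this assay, with compound 3 expected to land weaker than compound 2 by a step of a 3.5-fold higher number from compound 2 to compound 3 (0.54 log units; beyond the scatter), beyond the scatter. For compound 3 the estimate in this assay is 8000 nM, with a range of 2000 nM to 30000 nM.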

Compound 3, half-maximal effective concentration: > 1000000 nM
Compound 3 was reported as a limit (the forecaster's own chance of this, stated with the estimate: 15%); at least 120-fold (2.09 log units) between middle value and limit.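

In this assay, for the compounds shown here, the change from methyl to butyl, propyl in place of hydrogen on a saturated chain carbon bound to an aromatic carbon, gives an at least 430-fold higher number from compound 2 to compound 3 (2.63 log units; beyond the scatter), the first step that lies beyond the scatter. The readings of compound 1 and compound 2 could not be told apart, and they showed nothing about chain length; this step shows that the reading at this place depends strongly on what the ring carries, with butyl far from methyl. The reading of compound 3 is a limit and not a number, so the true size of the step remains unknown: the limit of > 1000000 nM in this assay, at which 1 of the 3 values shown sits.

The compounds shown leave open how the reading runs through an ethyl or a propyl chain at this place, so it cannot be said whether the change sets in gradually or only at butyl. One step also cannot tell whether chain length alone matters here, or whether a branched chain, a methoxymethyl group or an amine at the same place would behave in the same way.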